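The compounds below may be only part of what the source reports. "The series", "measured", "known", "first", "only" and "open" are said of these compounds alone.

Measured so far:
- compound 1 `C=C(Br)C(=O)Nc1cccc(/C=C2\SC(=O)N(Cc3ccc(Cl)cc3)C2=O)c1`: 1600 nM
- compound 2 `C=C(Br)C(=O)Nc1cccc(/C=C2\SC(=O)N(Cc3ccc(C(C)(C)C)cc3)C2=O)c1`: 5200 nM

Compound 1 holds the lowest of the two numbers in a functional assay on FM3A cells (Mus musculus) for cytotoxicity, read by cell counting, with a stated time of 2 days; on this read-out higher numbers stand for weaker inhibition and lower numbers for stronger inhibition; the nearest is compound 2, reached by a 3.3-fold higher number from compound 1 to compound 2 (0.51 log units; beyond the scatter), where the change is tert-butyl in place of chloro on an aromatic carbon.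

Compound 3 `Nc1cccc(/C=C2\SC(=O)N(Cc3ccc(Cl)cc3)C2=O)c1` is not yet measured in this assay. It differs from compound 1 by hydrogen in place of (1-bromoethenyl)carbonyl on a nitrogen on an aromatic ring, which may also be read as ((1-bromoethenyl)carbonyl)amino becoming amino.

Among the measured compounds shown here, no measured step touches this position; the only measured step, from compound 1 to compound 2, alters the other aromatic ring and is modest. The expected step is therefore unsupported by a shown pair and is taken with a wide range.

Compound 3 is expected to sit at 6000 nM, between 1500 nM and 25000 nM, an estimated step of a 3.8-fold higher number from compound 1 to compound 3 (0.57 log units; beyond the scatter).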

Compound 3, half-maximal inhibitory concentration: 246000 nM
For compound 3 the middle estimate is 41-fold (1.61 log units) below the measured one; the whole stated range lies below it.
By their numbers in this assay, from the lowest: compound 1; then compound 2; then compound 3.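

In this assay, the (1-bromoethenyl)carbonyl on the nitrogen matters far more than the aromatic substituent changed in the earlier pair: a 150-fold higher number from compound 1 to compound 3 (2.19 log units; beyond the scatter), against only a 3.3-fold higher number from compound 1 to compound 2 (0.51 log units; beyond the scatter). The free amino on the core of compound 1 therefore does not retain the low number of compound 1, so the read-out in this short series depends chiefly on this acyl group. Nothing available explains the size of this step.

The compounds shown do not separate the contributions of the bromine, the double bond and the carbonyl, and an acetyl or a propenoyl on the same nitrogen, or a (1-chloroethenyl)carbonyl, would divide the group into its parts. Going by these compounds, whether the step is of similar size with tert-butyl in place of chloro also remains open.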